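The compounds below may be only part of what the source reports. "The series", "measured", "known", "first", "only" and "open" are said of these compounds alone.

Measured in a functional assay on Ehrlich cells (Mus musculus) for cytotoxicity, read by trypan blue exclusion, with a stated time of 2 h; a higher number here means a weaker inhibitor, a lower number a stronger inhibitor:
- Compound 1 `N#CC1=C(N)N(c2ccc(S(N)(=O)=O)cc2)C2=C(C(=O)CCC2)C1c1ccc(Cl)cc1Cl` gives 25 ug/mL
- Compound 2 `Cc1ccc(C(=O)NC2=C(C#N)C(c3ccc(Cl)cc3Cl)C3=C(CCCC3=O)N2c2ccc(S(N)(=O)=O)cc2)cc1` gives > 100 ug/mL (a limit)
- Compound 3 `NC1=C(C(=O)O)C(c2ccc(Cl)cc2Cl)C2=C(CCCC2=O)N1c1ccc(S(N)(=O)=O)cc1` gives > 100 ug/mL (a limit)

Compound 2 stands at > 100 ug/mL, which is a limit of the assay and not a number. Within the data shown here, it shares that place with compound 3, so the series offers only one true number, and the picture is the limit of > 100 ug/mL in this assay, at which 2 of the 3 values shown sit.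

The next compound is compound 4 `CC(=O)CC(=O)NC1=C(C#N)C(c2ccc(Cl)cc2Cl)C2=C(CCCC2=O)N1c1ccc(S(N)(=O)=O)cc1`. It carries 2-oxopropyl in place of 4-methylphenyl on a carbonyl carbon. The amide-type nitrogen stays acylated, and the nitrile is kept.

Two measured steps are available. The closer one is an at least 4.0-fold higher number from compound 1 to compound 2 (0.60 log units; beyond the scatter), which placed an acyl group on the amine nitrogen, as compound 4 also has. The other, an at least 4.0-fold higher number from compound 1 to compound 3 (0.60 log units; beyond the scatter), replaced cyano with carboxy and touches a part of the molecule that does not change here. Among the measured compounds shown here, no measured step varies the group on the carbonyl carbon itself, so the size of this exchange remains untested.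

In this assay no change beyond the scatter is therefore expected, with the estimated step being an at least 1.1-fold lower number from compound 2 to compound 4 (0.04 log units; that floor lies within the scatter). If anything moves, a slightly lower number is the more likely direction, since the limit leaves compound 2 without a true value.

For compound 4 the estimate is 90 ug/mL, with an expected range from 35 ug/mL to 200 ug/mL.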

Compound 4, half-maximal inhibitory concentration: 64 ug/mL
The estimate for compound 4 lay 1.4-fold (0.15 log units) above the measured number, within the range that was stated.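

In this assay, among these compounds, compound 4 gives the first true number for an acylated amine nitrogen, which allows the effect of acylation at this position to be sized: a 2.6-fold higher number from compound 1 to compound 4 (0.41 log units; beyond the scatter). Among the compounds shown here, this step is modest but beyond the scatter, and it shows that a (2-oxopropyl)carbonyl group on this nitrogen leaves compound 4 with a measurable value, whereas the earlier compounds gave only a lower bound for acylation. The exchange of 4-methylphenyl for 2-oxopropyl on the carbonyl carbon gives an at least 1.5-fold lower number from compound 2 to compound 4 (0.19 log units; that floor lies within the scatter), and a floor within the scatter does not establish that this exchange matters. The value of compound 2 is a limit and not a number, so the true size of the exchange remains unknown: the limit of > 100 ug/mL in this assay, at which 2 of the 4 values shown sit.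

The compounds shown leave open how a methyl group, a longer chain or an amine on this carbonyl carbon would read, as only 4-methylphenyl and 2-oxopropyl stand there. They also leave open how a carboxylic acid in place of the nitrile would read when the amine nitrogen is acylated.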